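Working notes: from compound 3 to compound 4

A few compounds are considered here, and "the series" means these few. Any claim that something is new, unique, unknown or untested is made for them only; others in the source may bear on it.

- compound 1 `COc1ccc(C(=O)/C=C/c2ccc(F)cc2)c2c1C=CC(C)(C)O2` gives > 10000 nM (a limit)
- compound 2 `COc1ccc(C(=O)/C=C/c2ccc(Br)cc2)c2c1C=CC(C)(C)O2` gives > 10000 nM (a limit)
- compound 3 `COc1ccc(C(=O)/C=C/c2cccc([N+](=O)[O-])c2)c2c1C=CC(C)(C)O2` gives 8050 nM (a number)

In a functional assay on HCT-116 cells (Homo sapiens) for antiproliferative activity, read by MTT assay, with a stated time of 24 h (on this read-out higher numbers stand for weaker inhibition and lower numbers for stronger inhibition), compound 3 gives 8050 nM and is the only one of the three with a number. The entry for compound 1 is a limit. The entry for compound 2 is also a limit.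

Compound 4 `COc1ccc(C(=O)/C=C/c2ccco2)c2c1C=CC(C)(C)O2` differs from compound 3 in one place (furan-2-yl in place of 3-nitrophenyl on a double-bonded chain carbon bound to a double-bonded chain carbon), with furan-2-yl in place of 3-nitrophenyl on a double-bonded chain carbon bound to a double-bonded chain carbon.

Two measured steps change the group at this same place: an at least 1.2-fold lower number from compound 1 to compound 3 (0.09 log units; that floor lies within the scatter) and an at least 1.2-fold lower number from compound 2 to compound 3 (0.09 log units; that floor lies within the scatter). Both are only floors, and both floors lie within the scatter. The step that the two limits leave unreadable from compound 1 to compound 2 adds no size. None of these steps involves furan-2-yl, so they give no direction for the change, and no step beyond the scatter is expected in this assay. A reported limit for compound 4 is also a likely outcome.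

The estimated step is a 1.1-fold higher number from compound 3 to compound 4 (0.05 log units; within the scatter) (expected, not measured). For compound 4 the expected value is 9000 nM, with an estimated range from 3500 nM to 20000 nM.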

Compound 4, half-maximal inhibitory concentration: > 10000 nM
Compound 4: a limit, no number; the forecaster's own chance of this, stated with the estimate: 45%; middle value at least 1.1-fold (0.04 log units) away from the limit.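

Compound 4 carries a five-membered aromatic ring with one hetero atom at this place, on a double-bonded chain carbon bound to a double-bonded chain carbon, and in this assay the change from 3-nitrophenyl to furan-2-yl gives an at least 1.2-fold higher number from compound 3 to compound 4 (0.09 log units; that floor lies within the scatter). With only a floor inside the scatter, this step sets no order between the two groups, but replacing the six-membered aromatic ring with this five-membered one brings no value lower than that of compound 3. The steps from compound 1 and from compound 2 to compound 4 cannot be read, and the series remains largely at the edge of the measurable range: the limit of > 10000 nM in this assay, at which 3 of the 4 values shown sit.

From the compounds shown here alone, how far compound 1, compound 2 and compound 4 lie beyond their shared limit remains open, so the 4-fluorophenyl, 4-bromophenyl and furan-2-yl groups cannot be ordered. Also open, going by these compounds, is whether a thiophen-2-yl, a pyridin-3-yl, or a phenyl ring bearing an amine or a carboxylic acid at this place would give a value clearly lower than that of compound 3.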